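A Chlorine Returns in Place of the Dimethoxy Pattern

The compounds below may be only part of what the source reports. "The series", "measured", "known", "first", "only" and "open" are said of these compounds alone.

Compound 2 `COc1ccc(C2Oc3ccccc3N(CCCCCN3C(C)CCCC3C)C2=O)cc1OC` was examined in an assay on isolated protein for inhibition of serine protease 1 (Homo sapiens), tested at 100 uM (a higher number here means more inhibition at the concentration tested (going by the name of the read-out), a lower number less inhibition), and gave 0%. This is the lowest of the two numbers available, the nearest being compound 1 `CC1CCCC(C)N1CCCCCN1C(=O)C(c2ccc(Cl)c(Cl)c2)Oc2ccccc21`, which in this assay gives 14%. For the measured compounds named here, the single measured step that bears on the present question is a number 14 percentage points lower from compound 1 to compound 2 (beyond the scatter). Compound 3 `CC1CCCC(C)N1CCCCCN1C(=O)C(c2ccc(Cl)cc2)Oc2ccccc21` has not yet been measured. It differs from compound 2 as follows: 4-chlorophenyl in place of 3,4-dimethoxyphenyl on a saturated ring carbon. Since the 3,4-dichlorophenyl group on the saturated ring carbon went with the higher of the two numbers, and the 4-chlorophenyl group keeps a chlorine while the methoxy groups are gone, the change is expected to recover part of the drop seen from compound 1 to compound 2, though the recovery may well stay within the scatter of the read-out. The estimate for compound 3 in this assay is 8%, with a range from 0% to 20%, which amounts to an expected step of a number 8 percentage points higher from compound 2 to compound 3 (within the scatter).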

Compound 3, a percentage reported as inhibition, at one concentration (the size of the read-out at that concentration, not a potency): 46%
Estimate against measurement, compound 3: 38 percentage points below, outside the stated range (above it).
By their numbers in this assay, from the lowest: compound 2; then compound 1; then compound 3.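

Placing 4-chlorophenyl instead of 3,4-dimethoxyphenyl on the saturated ring carbon next to the ring oxygen gives a number 46 percentage points higher from compound 2 to compound 3 (beyond the scatter) in this assay, so this position can separate a compound with almost no inhibition from one with clear inhibition at the concentration tested. The earlier pair showed only a modest advantage for 3,4-dichlorophenyl over 3,4-dimethoxyphenyl, whereas hydrogen in place of chloro on an aromatic carbon gives a number 32 percentage points higher from compound 1 to compound 3 (beyond the scatter) and shows that the second chlorine is not needed for inhibition here. Among these three compounds, therefore, the number does not simply rise with the count of chlorines, and compound 1 goes against any such reading.

The compounds shown leave open whether the gain belongs to the chlorine itself or to the single substituent on the phenyl ring, a question that 4-fluorophenyl, 4-methoxyphenyl or unsubstituted phenyl at this position would address, and also whether it would hold with a shorter chain. Nothing available on these compounds gives a reason for this order.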